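This account rests on a few compounds, and the source may have more. Where it says the series, first, only, none or still open, it means among the compounds named here.

Compounds measured so far in an assay on CHO cells for antagonist activity at transient receptor potential cation channel subfamily V member 1 (Homo sapiens), read by scintillation counting, with a stated time of 5 min, in the presence of a further agent that is not named here; a higher number here means that more compound is needed for the effect, a lower number that less compound is needed:

- compound 1, `CN(C)C1(Cc2ccccc2)CCN(c2cc(C(F)(F)F)ccc2CNC(=O)Nc2ccc(CO)c(F)c2)CC1`: 81 nM
- compound 2, `CN(C)C1(Cc2ccccc2)CCN(c2cc(C(F)(F)F)ccc2CNC(=O)Nc2cccc3ccc(O)cc23)CC1`: 8.9 nM
- compound 3, `CN(C)C1(Cc2ccccc2)CCN(c2cc(C(F)(F)F)ccc2CNC(=O)Nc2ccc3c(c2)OCC3)CC1`: 31.3 nM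

Compound 3 stands second highest of the three numbers. Its nearest neighbour is compound 1, which gives 81 nM, a modest step of a 2.6-fold lower number from compound 1 to compound 3 (0.41 log units; beyond the scatter); its furthest is compound 2, which gives 8.9 nM, a step of a 3.5-fold higher number from compound 2 to compound 3 (0.55 log units; beyond the scatter).

Compound 4, `CN(C)C1(Cc2ccccc2)CCN(c2cc(C(F)(F)F)ccc2CNC(=O)Nc2cccc3c(=O)[nH]ccc23)CC1`, differs from compound 3 in one place: a group of 11 heavy atoms (9 carbon, 1 nitrogen, 1 oxygen; one six-membered aromatic ring of carbon only, one six-membered aromatic ring with 1 hetero atom) in place of a group of 9 heavy atoms (8 carbon, 1 oxygen; one five-membered non-aromatic ring with 1 hetero atom, one six-membered aromatic ring of carbon only), on an amide-type nitrogen. For the measured compounds named here, the group that enters is, like the group on compound 2, a fused pair of six-membered aromatic rings carrying one hydrogen-bond donor, whereas the group that leaves is the one on compound 3. Going by the values given here, the step that bears most directly on this change is therefore the one between compound 2 and compound 3, which was a 3.5-fold higher number from compound 2 to compound 3 (0.55 log units; beyond the scatter); the step of a 2.6-fold lower number from compound 1 to compound 3 (0.41 log units; beyond the scatter) is a weaker guide, since compound 1 carries only a single ring. Running the first of these steps in reverse suggests a modest lower number, beyond the scatter, in this assay. Compound 4 is thus expected to give 12 nM, within a range of 4 nM to 35 nM, a step of a 2.6-fold lower number from compound 3 to compound 4 (0.42 log units; beyond the scatter).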

Compound 4, half-maximal effective concentration: "not active" (no number reported)
For compound 4 the study gives words and no number; no gap can be computed for the estimate.
By their numbers in this assay, from the lowest: compound 2; then compound 3; then compound 1.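

In this assay, for the compounds shown here, compound 4 is reported only in words, as not active, so no step from compound 3 to compound 4 can be read. Nothing shown here bears on the reason for this result. The compounds shown leave open how much compound 4 would be needed for the effect, and which part of its entering group goes with this result.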